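Replacing 4-nitrophenyl with 2,3,4-trimethoxyphenyl: working notes

This account rests on a few compounds, and the source may have more. Where it says the series, first, only, none or still open, it means among the compounds named here.

In a functional assay on MCF7 cells (Homo sapiens) for cytotoxicity, read by MTT assay, with a stated time of 72 h (a lower number here means a stronger inhibitor, a higher number a weaker inhibitor), compound 1 `O=C(/C=C/c1ccc([N+](=O)[O-])cc1)Nc1cc2c(Nc3ccc(F)c(Cl)c3)ncnc2cc1O[C@H]1CCOC1` gives 26700 nM as its reading. In this assay compound 3 `COc1ccc(OC)c(/C=C/C(=O)Nc2cc3c(Nc4ccc(F)c(Cl)c4)ncnc3cc2OC)c1` gives 34300 nM and lies within the scatter of compound 1. Compound 2 `COc1cc2ncnc(Nc3ccc(F)c(Cl)c3)c2cc1NC(=O)/C=C/c1ccc(F)cc1Cl` has no number and is recorded as "not active" (no number reported) in these notes. Going by the values given here, compound 4 `COc1ccc(/C=C/C(=O)Nc2cc3c(Nc4ccc(F)c(Cl)c4)ncnc3cc2O[C@H]2CCOC2)c(OC)c1OC` has 2,3,4-trimethoxyphenyl in place of 4-nitrophenyl on a double-bonded chain carbon bound to a double-bonded chain carbon as its only change. Among the compounds with values here, no measured pair isolates this change. Compound 3 also carries methoxy groups on its aromatic ring and reads 34300 nM in line with compound 1. In this assay the expected move is a 1.0-fold higher number from compound 1 to compound 4 (0.00 log units; within the scatter) and no larger than the scatter. Compound 4 is expected at 27000 nM within a range of 11000 nM to 65000 nM in this estimate.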

Compound 4, half-maximal inhibitory concentration: 4650 nM
Beside the measured number, compound 4's estimate is 5.8-fold (0.76 log units) above it, outside the stated range (below it).
By their numbers in this assay, from the lowest: compound 4; then compounds 1 and 3 (each within the scatter of the next).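

In this assay, going by these compounds alone, 2,3,4-trimethoxyphenyl in place of 4-nitrophenyl on a double-bonded chain carbon bound to a double-bonded chain carbon gives a 5.7-fold lower number from compound 1 to compound 4 (0.76 log units; beyond the scatter) and is the only step here that isolates a change at this position. Within the data shown here, it shows that the number responds to the aryl group held at this place, which the earlier compounds, differing in more than one place, could not show. No evidence on the origin of this step is available. From the compounds shown here alone, whether an aminophenyl or a carboxyphenyl group at this place would read like compound 4 stays open.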